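The source may report more compounds than this note shows. Statements on the series, on what has been measured and on what is new or still open speak of the compounds shown alone.

Working notes on the series.

Two compounds have been run so far in a functional assay on PC-3 cells (Homo sapiens) for antiproliferative activity, read by MTT assay, with a stated time of 48 h; on this read-out higher numbers stand for weaker inhibition and lower numbers for stronger inhibition. Compound 1, `COc1ccc(N/C=C\C(=O)c2cn(-c3ccccc3)nc2-c2ccc(Cl)cc2)cc1`, gives 10700 nM in this assay. Compound 2, `COc1cc(-c2nn(-c3ccccc3)cc2C(=O)/C=C\Nc2ccc(Cl)cc2)cc(OC)c1OC`, gives 11200 nM in this assay. The two numbers sit within the scatter of each other, so nothing separates compound 1 from compound 2 on this read-out; both lie in the same weak range. For the measured compounds named here, no step between measured compounds that differ in a single place is available in the set.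

The next compound is compound 3, `COc1cc(-c2nn(-c3ccccc3)cc2C(=O)/C=C\Nc2ccc(O)cc2)cc(OC)c1OC`. Compared with compound 2 the change is hydroxy in place of chloro on an aromatic carbon. The remainder of the structure is unchanged. Going by the values given here, no measured pair in the set shows what this exchange does, so there is no basis for predicting a step in either direction beyond the scatter. The expectation is that the step from compound 2 to compound 3 in this assay, a 1.1-fold higher number from compound 2 to compound 3 (0.03 log units; within the scatter), stays within the usual scatter. Compound 3 is thus estimated at 12000 nM in this assay, with a plausible range from 5000 nM to 30000 nM.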

Compound 3, half-maximal inhibitory concentration: 4600 nM
The estimate for compound 3 lay 2.6-fold (0.42 log units) above the measured number; the whole stated range lies above it.
By their numbers in this assay, from the lowest: compound 3; then compounds 1 and 2 (each within the scatter of the next).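

In this assay, the exchange of (4-chlorophenyl)amino for (4-hydroxyphenyl)amino gives a 2.4-fold lower number from compound 2 to compound 3 (0.39 log units; beyond the scatter), a modest step and the first in the series to lie beyond the scatter. This shows that the substituent on this aromatic carbon, para to a large group, can move the read-out, and that hydroxy gives the stronger inhibition of the two groups compared here, although compound 3 rests on a single exchange in one background. The entering hydroxy brings a hydrogen-bond donor and a hydrogen-bond acceptor that chloro does not have, but no measurement in hand links either feature to the step, so the reason for the shift remains unexplained.

The compounds shown leave open whether the gain is specific to hydroxy or would also appear with another group at this place, such as methoxy, an amine or a carboxylic acid. They also leave open whether the same exchange would give a step of similar size on the background of compound 1, which carries 4-chlorophenyl on the core in place of the trimethoxy-substituted aryl group.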